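Aryl swap on the aromatic nitrogen of the shared core

The compounds below may be only part of what the source reports. "The series", "measured", "known", "first", "only" and "open" are said of these compounds alone.

Measured compounds:
Compound 1 `COc1cc2c(Oc3ccc(NC(=O)c4nn(-c5ccccc5Br)c(=O)c5ccccc45)cc3F)ccnc2cc1OCCCN1CCCC1` in a functional assay on MDA-MB-231 cells (Homo sapiens) for cytotoxicity, read by MTT assay, with a stated time of 72 h (a higher number here means a weaker inhibitor, a lower number a stronger inhibitor), gives 1020 nM.
Compound 2 `COc1cc2c(Oc3ccc(NC(=O)c4nn(-c5ccccc5Br)c(=O)c5ccccc45)cc3F)ccnc2cc1OCCCN1CCN(C)CC1` in this assay gives 1680 nM.
Compound 3 `COc1cc2c(Oc3ccc(NC(=O)c4nn(-c5cccc(F)c5)c(=O)c5ccccc45)cc3F)ccnc2cc1OCCCN1CCC(C)CC1` in this assay gives 860 nM.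

Compound 3 holds the lowest number of the three, but its gaps to compound 1 and to compound 2 both lie within the scatter, so no order among them can be claimed. Compound 4 `COc1cc2c(Oc3ccc(NC(=O)c4nn(-c5ccccc5Br)c(=O)c5ccccc45)cc3F)ccnc2cc1OCCCN1CCC(C)CC1` carries 2-bromophenyl in place of 3-fluorophenyl on an aromatic nitrogen. Among the compounds with values here, the only single-place step on record, a 1.6-fold higher number from compound 1 to compound 2 (0.22 log units; within the scatter), changes the group on the saturated chain carbon and says nothing about the aryl on the aromatic nitrogen; compound 1 and compound 3 differ in two places at once, so their values are only two numbers side by side. Within the data shown here, no measured step therefore bears on this change, and no step beyond the scatter in this assay is expected. Compound 4 is estimated at 950 nM, range 480 nM to 1900 nM, with a step of a 1.1-fold higher number from compound 3 to compound 4 (0.04 log units; within the scatter) expected.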

Compound 4, half-maximal inhibitory concentration: 1240 nM
For compound 4 the middle estimate is 1.3-fold (0.12 log units) below the measured one, within the range that was stated.
By their numbers in this assay, from the lowest: compounds 3, 1, 4 and 2 (each within the scatter of the next).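

In this assay, the aryl on the aromatic nitrogen now has a single-place reading: a 1.4-fold higher number from compound 3 to compound 4 (0.16 log units; within the scatter), so 2-bromophenyl and 3-fluorophenyl cannot be told apart here when the chain ends in 4-methylpiperidin-1-yl. The chain end also gains two readings, a 1.4-fold lower number from compound 2 to compound 4 (0.13 log units; within the scatter) and a 1.2-fold higher number from compound 1 to compound 4 (0.08 log units; within the scatter), and neither separates 4-methylpiperidin-1-yl from the other two rings. No evidence bears on these results.

Open, on these data alone, is whether an aminophenyl or carboxyphenyl group on the aromatic nitrogen would move the number beyond the scatter. Also open, as far as these compounds go, is whether the aryl reading holds with a pyrrolidin-1-yl chain end.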